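The compounds below may be only part of what the source reports. "The series", "measured", "known", "first", "only" and "open" are said of these compounds alone.

Of the compounds shown here, three that share one core have been measured in an ADME assay on MT4 cells (Homo sapiens) for cytotoxicity, read by XTT assay, with a stated time of 5 days; a higher number here means that more compound is tolerated, a lower number that less compound is tolerated. There, compound 1 `C=CCNC(=O)[C@@H](NC(=O)[C@@](O)(CCCN(Cc1ccc(Br)cc1)NC(=O)[C@@H](NC(=O)OC)C(C)(C)C)Cc1ccc(C=C)cc1)C(C)(C)C` gives 44000 nM, compound 2 `C=CCNC(=O)[C@@H](NC(=O)[C@](O)(CCCN(Cc1ccc(Br)cc1)NC(=O)[C@@H](NC(=O)OC)C(C)(C)C)Cc1ccc(C=C)cc1)C(C)(C)C` gives 25000 nM and compound 3 `C=CCNC(=O)[C@@H](NC(=O)[C@](O)(CCCN(Cc1ccc(Br)cc1)NC(=O)[C@@H](NC(=O)OC)C(C)(C)C)Cc1ccc(Br)cc1)C(C)(C)C` gives 21000 nM. The steps that link compound 2 to the other two both lie within the scatter, so its number holds no distinct rank.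

The next compound, compound 4 `C=CCNC(=O)[C@@H](NC(=O)[C@](O)(CCCN(Cc1ccc(Br)cc1)NC(=O)[C@@H](NC(=O)OC)C(C)(C)C)Cc1ccc(C=C)cc1)C(C)C`, departs from compound 2 in a single place: hydrogen in place of methyl on a saturated chain carbon bound to three saturated chain carbons. Put another way, tert-butyl becomes isopropyl, which turns the 1-(allylcarbamoyl)-2,2-dimethylpropyl group into 1-(allylcarbamoyl)-2-methylpropyl.

Neither measured step touches this group, so neither is a direct precedent. They show only how far the number has moved under other changes in this small set. One is a 1.8-fold lower number from compound 1 to compound 2 (0.25 log units; within the scatter), a step that reflects (the fact that compounds 1 and 2 differ only in the configuration as drawn). The other is a 1.2-fold lower number from compound 2 to compound 3 (0.08 log units; within the scatter), with bromo in place of vinyl on an aromatic carbon. Neither goes beyond the scatter, so no step beyond the scatter is expected in this assay here, and no direction can be favoured with any confidence. The expected change is a 1.1-fold higher number from compound 2 to compound 4 (0.03 log units; within the scatter). For compound 4 the estimated value is 27000 nM, with an expected range from 12000 nM to 60000 nM.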

Compound 4, half-maximal cytotoxic concentration: 5800 nM
The estimate for compound 4 lay 4.7-fold (0.67 log units) above the measured number; measured number below the stated range.
By their numbers in this assay, from the lowest: compound 4; then compounds 3, 2 and 1 (each within the scatter of the next, the first and the last beyond it).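

In this assay, the change from tert-butyl to isopropyl gives a 4.3-fold lower number from compound 2 to compound 4 (0.63 log units; beyond the scatter). Among the compounds shown here, this is the first step in the set to go beyond the scatter, while the change in drawn configuration and the swap of bromo for vinyl both stayed within it. So the position shows a sensitivity that the earlier compounds gave no sign of: losing a single methyl, which is one carbon with no ring, no hydrogen-bond donor or acceptor and no net charge, leaves less compound tolerated, though the step is still modest. Nothing in the information at hand bears on why this change moves the number.

This is a single pair, so it cannot show whether the number would keep moving in the same direction with other groups here, such as cyclohexyl, phenyl or a longer chain such as n-butyl. It also leaves open whether the same replacement would have a similar effect with the bromo group of compound 3 or the drawn configuration of compound 1, or at the second tert-butyl group these structures carry.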